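A few compounds are considered here, and "the series" means these few. Any claim that something is new, unique, unknown or untested is made for them only; others in the source may bear on it.

Three compounds built on one shared core, each carrying an ether on that core, have been tested in an assay on cells with melanin-concentrating hormone receptor 1 (Homo sapiens) as the target, read by radioligand binding; on this read-out higher numbers stand for weaker inhibition and lower numbers for stronger inhibition. Compound 1 `Nc1ccc2cccc(OC3CCC3)c2n1` carries a cyclobutyl on the ether oxygen. In this assay compound 1 gives > 2000 nM, which is a limit of the assay rather than a number (the limit of > 2000 nM in this assay, at which 1 of the 3 values shown sits). Compound 2 `CCC(C)COc1cccc2ccc(N)nc12` carries 2-methylbutyl in that place and gives 36 nM in this assay. Compound 3 `Nc1ccc2cccc(OCC3CCCC3)c2n1` carries cyclopentylmethyl and gives 53 nM in this assay. Both replacements of cyclobutyl brought large gains: an at least 55-fold lower number from compound 1 to compound 2 (1.74 log units; beyond the scatter) and an at least 37-fold lower number from compound 1 to compound 3 (1.57 log units; beyond the scatter). Between the two replacements themselves the difference is small, a 1.5-fold higher number from compound 2 to compound 3 (0.17 log units; within the scatter). Compound 4 `CC#CCCOc1cccc2ccc(N)nc12` has not yet been measured; it differs from compound 1 by pent-3-yn-1-yl in place of cyclobutyl on an oxygen on an aromatic ring. Since the two measured replacements of cyclobutyl, an at least 55-fold lower number from compound 1 to compound 2 (1.74 log units; beyond the scatter) and an at least 37-fold lower number from compound 1 to compound 3 (1.57 log units; beyond the scatter), both gave large gains, a step of comparable size is expected for compound 4, an at least 33-fold lower number from compound 1 to compound 4 (1.52 log units; beyond the scatter). Compound 4 is therefore estimated at 60 nM in this assay, with a range from 20 nM to 250 nM.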

Compound 4, half-maximal inhibitory concentration: > 2000 nM
Compound 4: only a limit was reported (the forecaster's own chance of this, stated with the estimate: 5%); at least 33-fold (1.52 log units) between middle value and limit.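

In this assay compound 4 ends at a limit of the assay, not a number: the limit of > 2000 nM in this assay, at which 2 of the 4 values shown sit. The result shows that moving away from cyclobutyl does not by itself bring the gain, and that a chain on the oxygen can lose nearly all of it: the change to but-2-yn-1-yl on the saturated chain carbon gives an at least 55-fold higher number from compound 2 to compound 4 (1.74 log units; beyond the scatter) and an at least 37-fold higher number from compound 3 to compound 4 (1.57 log units; beyond the scatter). Having no ring does not sort these compounds either, as compound 2 and compound 4 both lack one, yet only compound 2 gives a measured number.

Going by these compounds, the step between compound 1 and compound 4 cannot be read, as both are limits, so their order stays unknown. On these data alone, whether the triple bond or the chain's shape goes with the loss stays open, and a plain pentyl chain on the oxygen would help to separate the two.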